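Plasma stability of a triazene prodrug after loss of a hydroxy

This account rests on a few compounds, and the source may have more. Where it says the series, first, only, none or still open, it means among the compounds named here.

Of the compounds shown here, two have been measured in an ADME assay on a cell-free system (plasma, Homo sapiens) for metabolic stability; a lower number here means that the compound disappears faster, a higher number that the compound lasts longer. Compound 1, `CCOC(=O)c1ccc(/N=N/N(C)C(=O)OCOC(=O)c2ccccc2O)cc1`, gives 0.567 h in this assay. Compound 2, `CS(=O)(=O)N(COC(=O)c1ccccc1)c1ccc([N+](=O)[O-])cc1Oc1ccccc1`, gives 0.0322 h. Compound 1 thus holds the higher of the two numbers, and its distance to compound 2 lies beyond the scatter of the method. Among the compounds with values here, no step between two measured compounds that differ in a single place has been recorded, so the pair offers no direct guide to the change at hand.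

Compound 3, `CCOC(=O)c1ccc(/N=N/N(C)C(=O)OCOC(=O)c2ccccc2)cc1`, is the next compound to be measured. It differs from compound 1 in one place: hydrogen in place of hydroxy on an aromatic carbon, on an aromatic carbon of a six-membered aromatic ring of carbon only, ortho to a large group. Read one bond further out, the change is from a (2-hydroxyphenyl)carbonyl to a benzoyl.

Within the data shown here, with no measured step of this kind available, the expectation for compound 3 is a step from compound 1 of a 1.1-fold lower number from compound 1 to compound 3 (0.05 log units; within the scatter), most likely within the scatter and in no firm direction. Compound 3 is therefore estimated at 0.5 h, with a range from 0.2 h to 1.2 h.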

Compound 3, half-life: 0.783 h
For compound 3 the middle estimate is 1.6-fold (0.19 log units) below the measured one; measured number inside the range.
By their numbers in this assay, from the lowest: compound 2; then compounds 1 and 3 (each within the scatter of the next).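

In this assay, the change from hydroxy to hydrogen on an aromatic carbon, ortho to a large group, gives a 1.4-fold higher number from compound 1 to compound 3 (0.14 log units; within the scatter), so the two compounds cannot be told apart by their half-lives. Within the data shown here, this is the first step that differs in a single place, and it shows that going from a (2-hydroxyphenyl)carbonyl to a benzoyl, with the rest of the structure held constant, leaves the number within the scatter of the method in this assay. No measured information is available to explain why the pair reads alike.

The compounds shown leave open whether this position would stay as undemanding with a different group in place of the hydrogen, such as a methoxy, a fluorine, an amine or a carboxylic acid, or with a substituent at another carbon of the same ring. They also leave open whether the same change would give a similar step on a different core, or with a longer chain in place of the ethyl of the ester, where the hydroxy might count for more.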